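The source may hold more compounds than are shown below. What is called first, only, known or untested is meant among the compounds shown, and "the series" means these compounds.

Three compounds sharing one core were examined in a functional assay on MDA-MB-435 cells (Homo sapiens); on this read-out lower numbers stand for stronger inhibition of growth and higher numbers for weaker inhibition of growth. Compound 1 `COc1ccc(-c2cc(O)c3c(C)cc(C)nc3n2)cc1` gives 28800 nM. Compound 2 `COc1ccccc1-c1cc(O)c2cccnc2n1` gives 39800 nM, and compound 3 `COc1ccccc1-c1cc(O)c2c(C)ccnc2n1` gives 6460 nM. Compound 3 and compound 2 differ in one place, (hydrogen in place of methyl on an aromatic carbon), and that change produced a 6.2-fold higher number from compound 3 to compound 2 (0.79 log units; beyond the scatter). Compound 1 and compound 2 give numbers that lie within the scatter of each other, while compound 3 sits clearly lower than compound 1. How the cores of compound 1 and compound 3 differ is not broken down here.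

Compound 4 `COc1ccc(-c2cc(O)c3ccc(C)nc3n2)cc1` has not been measured. It is reached from compound 1 by hydrogen in place of methyl on an aromatic carbon, which is the same kind of change as that from compound 3 to compound 2; the place differs in that it is also meta to a methyl group. Because the earlier step gave a 6.2-fold higher number from compound 3 to compound 2 (0.79 log units; beyond the scatter), a step of similar direction is expected, and compound 4 is estimated to show a 3.1-fold higher number from compound 1 to compound 4 (0.49 log units; beyond the scatter). Compound 4 is therefore expected to give about 90000 nM, likely between 28000 nM and 300000 nM, in this assay.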

Compound 4, concentration for 50% growth inhibition: 42700 nM
Compound 4: the middle estimate sits 2.1-fold (0.32 log units) above what was measured, within the range that was stated.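

In this assay, replacing methyl by hydrogen on the core of compound 1 gave a 1.5-fold higher number from compound 1 to compound 4 (0.17 log units; within the scatter), a step that cannot be told apart from repeated measurement. The same change therefore did not carry over at the same size from one core to the other: the same change on two cores in this assay, a 6.2-fold higher number (0.79 log units; beyond the scatter) from compound 3 to compound 2 and a 1.5-fold higher number (0.17 log units; within the scatter) from compound 1 to compound 4, 4.2-fold (0.62 log units) apart, beyond the scatter of two such steps This shows that, for these two pairs, the size of the step depends on the core that carries it, so the step seen on one core gives a poor guide to the step on the other; it does not show which feature of the two cores is responsible, and two pairs set no rule for the wider series.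

The compounds shown carry only methyl or hydrogen at the places compared, which leaves open how an ethyl group, an amine or a chlorine atom there would read in this assay. As far as these compounds go, whether either step would hold on a third core also remains open.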